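The source may hold more compounds than are shown below. What is called first, only, known or untested is meant among the compounds shown, and "the series" means these compounds.

Measured so far:
Compound 1 `O=C(O)CCNC(=O)c1ccc(C(Oc2ccc(-n3cc(C(F)(F)F)cn3)cc2)C2CC2)cc1` in a functional assay on cells for antagonist activity at Glucagon receptor (Homo sapiens), read by cAMP accumulation, in the presence of a further agent that is not named here (a lower number here means a stronger inhibitor, a higher number a weaker inhibitor), gives 15000 nM.
Compound 2 `CC(C)CC(Oc1ccc(-n2cc(C(F)(F)F)cn2)cc1)c1ccc(C(=O)NCCC(=O)O)cc1` in this assay gives 3400 nM.

Compound 2 stands at the lower of these two numbers, with compound 1 sitting above it by a 4.4-fold lower number from compound 1 to compound 2 (0.64 log units; beyond the scatter). Compound 3 `CCCC(Oc1ccc(-n2cc(C(F)(F)F)cn2)cc1)c1ccc(C(=O)NCCC(=O)O)cc1` differs from compound 2 by hydrogen in place of methyl on a saturated chain carbon bound to two saturated chain carbons; in other words, isobutyl becomes propyl. Among the measured compounds shown here, the only step bearing on this place is the change from cyclopropyl to isobutyl, a 4.4-fold lower number from compound 1 to compound 2 (0.64 log units; beyond the scatter), which points toward larger groups giving lower numbers. Taking away one carbon is therefore expected to raise the number modestly, a 2.1-fold higher number from compound 2 to compound 3 (0.31 log units; beyond the scatter). Compound 3 is expected to give about 7000 nM, within 2500 nM to 20000 nM.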

Compound 3, antagonist equilibrium constant: 5100 nM
The estimate for compound 3 lay 1.4-fold (0.14 log units) above the measured number, within the range that was stated.
By their numbers in this assay, from the lowest: compounds 2 and 3 (each within the scatter of the next); then compound 1.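

In this assay, trimming isobutyl to propyl on a saturated chain carbon bound to two saturated chain carbons gives a step that stays within the scatter (a 1.5-fold higher number from compound 2 to compound 3 (0.18 log units; within the scatter)), so the methyl that leaves makes no readable difference. Propyl remains clearly separated from cyclopropyl (a 2.9-fold lower number from compound 1 to compound 3 (0.47 log units; beyond the scatter)), which puts both open chains on the same side of that comparison. No supporting measurement explains these results. Going by these compounds, whether a longer chain such as butyl would lower the number remains open. So does the effect of a cyclobutyl ring or a chain bearing an amine.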